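Working notes on an indole amine oxidase inhibitor series

The compounds below may be only part of what the source reports. "The series", "measured", "known", "first", "only" and "open" are said of these compounds alone.

compound 1 `C#CCN(C)Cc1cn(Cc2ccccc2)c2ccccc12` gives 476000 nM
compound 2 `CC#CCNCc1cc2cc(OCc3ccccc3)ccc2[nH]1` gives 15 nM
compound 3 `CC#CCN(C)Cc1cc2ccccc2n1C` gives 30 nM

In an assay on isolated protein for inhibition of Amine oxidase [flavin-containing] B (Rattus norvegicus) (a lower number here means a stronger inhibitor, a higher number a weaker inhibitor), compound 1 stands at the highest of the three numbers. The nearest is compound 3, whose number is lower by a gap beyond the usual scatter; the furthest is compound 2, lower still and likewise beyond the scatter. Compound 4 `CC(C)NCc1cn(Cc2ccccc2)c2ccccc12` is the next member, differing from compound 1 by isopropylamino in place of methyl(propargyl)amino on a saturated chain carbon bound to an aromatic carbon. Among the compounds with values here, no single-change step between measured compounds is available to calibrate this change, so the expectation rests on compound 1 alone, which already sits very high in this assay. The step from compound 1 to compound 4 is expected to be a 2.1-fold higher number from compound 1 to compound 4 (0.32 log units; beyond the scatter), toward a higher number, and possibly to exceed what the assay can report. Compound 4 is estimated at 1000000 nM, within 200000 nM to 5000000 nM.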

Compound 4, inhibition constant: 438000 nM
Beside the measured number, compound 4's estimate is 2.3-fold (0.36 log units) above it; the measured number falls inside the stated range.
By their numbers in this assay, from the lowest: compounds 2 and 3 (each within the scatter of the next); then compounds 4 and 1 (each within the scatter of the next).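

In this assay, replacing methyl(propargyl)amino with isopropylamino on a saturated chain carbon bound to an aromatic carbon gives a 1.1-fold lower number from compound 1 to compound 4 (0.04 log units; within the scatter), so the two numbers cannot be told apart on this core. At this position, the propargyl group and its triple bond therefore confer no measurable gain over isopropylamino. No evidence on the reason accompanies this result.

As far as these compounds go, whether the same swap is as silent on the cores of compound 2 and compound 3 remains open. So does whether a dimethylamino or cyclopropylamino group at this carbon would shift the number.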